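Exchanging the group on the ring amine nitrogen

The compounds below may be only part of what the source reports. "The series", "measured", "known", "first", "only" and "open" are said of these compounds alone.

Measured compounds:
compound 1, `CCCc1nc(-c2ccccc2)c(CNCCN2CCN(c3ccccc3F)CC2)o1`, giving 46.5% in an assay on HEK293 cells for inhibition of Voltage-dependent T-type calcium channel subunit alpha-1G (Homo sapiens), read by fluorescence, tested at 10 uM; a higher number here means more inhibition at the concentration tested (going by the name of the read-out), a lower number less inhibition
compound 2, `CCCc1nc(-c2ccccc2)c(CNCCN2CCN(c3ccccc3OC)CC2)o1`, giving 39.7% in this assay

Compound 2 carries the lowest of the two numbers in this assay, and its nearest neighbour is compound 1, which sits above it by a difference that stays inside the usual scatter. Among the compounds with values here, the only measured step, a number 6.8 percentage points lower from compound 1 to compound 2 (within the scatter), consists of methoxy in place of fluoro on an aromatic carbon, and it did not rise above that scatter.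

Compound 3, `CCCc1nc(-c2ccccc2)c(CNCCN2CCN(c3ccc(F)cc3)CC2)o1`, is the next compound to be measured in this assay. Its difference from compound 2 is 4-fluorophenyl in place of 2-methoxyphenyl on an amine nitrogen in a ring. Within the data shown here, this change again trades a methoxy group for a fluoro group on the aromatic ring attached to the ring amine nitrogen, so the one measured step is the only guide, and it was small. No step beyond the scatter is therefore expected, so the estimated step is a number 5.3 percentage points higher from compound 2 to compound 3 (within the scatter). For compound 3 in this assay the expected value is 45%, with a plausible range from 25% to 65%.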

Compound 3, a percentage reported as inhibition, at one concentration (the size of the read-out at that concentration, not a potency): 54.1%
Compound 3: middle estimate off by 9.1 percentage points, on the low side, within the range that was stated.
By their numbers in this assay, from the lowest: compounds 2, 1 and 3 (each within the scatter of the next, the first and the last beyond it).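

In this assay, exchanging the group on the ring amine nitrogen now gives a step that rises above the scatter: (a number 14.4 percentage points higher from compound 2 to compound 3 (beyond the scatter)), with 4-fluorophenyl in place of 2-methoxyphenyl. The other new comparison, 4-fluorophenyl in place of 2-fluorophenyl, gives (a number 7.6 percentage points higher from compound 1 to compound 3 (within the scatter)), so the two fluorinated compounds cannot be told apart in this read-out, and the position of the fluorine on the ring shows no clear effect here. Since the group that leaves and the group that enters differ in both the substituent and its place on the ring, compound 2 and compound 3 alone cannot show which of the two differences accounts for the step, and no further measurement bears on the reason for it.

The compounds shown leave open how this position responds to other substituents on the aromatic ring, such as a chlorine atom, a nitrile or a carboxylic acid. They also leave open how the compounds compare in potency, as each number comes from a single tested concentration.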